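A few compounds are considered here, and "the series" means these few. Any claim that something is new, unique, unknown or untested is made for them only; others in the source may bear on it.

Series notes. The shared core carries a trimethoxyphenyl group and varies the aryl group on an aromatic carbon of the fused bicyclic ring. In a functional assay on HeLa cells (Homo sapiens) for inhibition, read by CCK-8 assay, with a stated time of 48 h (on this read-out lower numbers stand for stronger inhibition and higher numbers for weaker inhibition), compound 1 `COc1cc(-c2ccnc3cc(-c4ccc(Cl)cc4)nn23)cc(OC)c1OC` gives 1490 nM. Compound 2 `COc1cc(-c2ccnc3cc(-c4c[nH]c5ccccc45)nn23)cc(OC)c1OC` gives 195 nM in this assay, and compound 3 `COc1cc(-c2ccnc3cc(-c4ccc5ccn(C)c5c4)nn23)cc(OC)c1OC` gives 187 nM. Compound 3 has the lowest of the three numbers, but its separation from compound 2 is within the scatter, so the two cannot be ordered; the clear step is an 8.0-fold lower number from compound 1 to compound 3 (0.90 log units; beyond the scatter), matched by a 7.6-fold lower number from compound 1 to compound 2 (0.88 log units; beyond the scatter), while a 1.0-fold lower number from compound 2 to compound 3 (0.02 log units; within the scatter).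

Compound 4 `COc1cc(-c2ccnc3cc(-c4ccc5cnn(C)c5c4)nn23)cc(OC)c1OC` is not yet measured. It differs from compound 3 in one place: 1-methyl-1H-indazol-6-yl in place of 1-methyl-1H-indol-6-yl on an aromatic carbon. Among the compounds with values here, no measured step trades an indole for an indazole, so the change has no direct precedent here. What bears on it is that the two bicyclic replacements of 4-chlorophenyl each gave a lower number than compound 1, namely compound 2 with 195 nM and compound 3 with 187 nM, and that exchanging one bicyclic group for the other left the number unchanged within the scatter. The expectation is therefore that the number for compound 4 stays close to that of compound 3, with a 1.4-fold higher number from compound 3 to compound 4 (0.14 log units; within the scatter) expected, no step beyond the scatter in either direction. Compound 4 is estimated at 260 nM, with a range from 100 nM to 700 nM.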

Compound 4, half-maximal inhibitory concentration: 97 nM
Estimate against measurement, compound 4: 2.7-fold (0.43 log units) above; measured number below the stated range.
By their numbers in this assay, from the lowest: compounds 4, 3 and 2 (each within the scatter of the next); then compound 1.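

In this assay, within the data shown here, a second nitrogen in the five-membered ring of the bicyclic group is tolerated at this position: a 1.9-fold lower number from compound 3 to compound 4 (0.29 log units; within the scatter) is the first direct indole-to-indazole comparison, and with a 2.0-fold lower number from compound 2 to compound 4 (0.30 log units; within the scatter) it leaves compound 2, compound 3 and compound 4 unordered. Among these compounds, the gap to the single-ring group also widens to the only step graded large, a 15-fold lower number from compound 1 to compound 4 (1.19 log units; beyond the scatter), so all three bicyclic groups now stand clearly apart from 4-chlorophenyl, although that contrast rests on compound 1 alone. Nothing available explains why the indazole behaves as it does at this position.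

It remains open whether the methyl on the ring nitrogen of the indazole matters, as neither the unsubstituted 1H-indazol-6-yl group nor a longer chain such as propyl in its place appears among these compounds. Also open, on these data alone, is how this position responds to a basic amine or a carboxylic acid on the bicyclic group, and whether a single ring such as pyridine would behave like 4-chlorophenyl or like the bicyclic groups.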